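The source may hold more compounds than are shown below. What is called first, only, known or untested is meant among the compounds shown, and "the series" means these compounds.

Measured in a toxicity assay on Hepa-1c1c7 cells (Mus musculus) for inhibition; on this read-out higher numbers stand for weaker inhibition and lower numbers for stronger inhibition:
Compound 1 `CCCCCC(O)C#CC#CCO`: > 50000 nM (a limit)
Compound 2 `CCCCCC(O)C#CC#CC(O)CC(C)C`: 41000 nM
Compound 3 `CCCCCCCCCC(O)C#CC#CC(O)CCCCCCCCC`: 26000 nM

Compound 3 gives 26000 nM, within the scatter of compound 2 at 41000 nM. Compound 4 `CCCCCCCCCC(O)C#CC#CC(O)CC(C)C` carries isopropyl in place of octyl on a saturated chain carbon, two bonds along the chain from an oxygen on a saturated carbon and a triple-bonded carbon. Going by the values given here, the only measured single-place step is an at least 1.2-fold lower number from compound 1 to compound 2 (0.08 log units; that floor lies within the scatter); it starts from a limit and stays within the scatter. No shift beyond the scatter is therefore expected in this assay. The expected step is a 1.2-fold higher number from compound 3 to compound 4 (0.08 log units; within the scatter). For compound 4 the estimated value is 31000 nM, with an expected range of 16000 nM to 55000 nM.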

Compound 4, half-maximal inhibitory concentration: > 50000 nM
Compound 4 ended at the assay's limit; the forecaster's own chance of this, stated with the estimate: 15%; middle value at least 1.6-fold (0.20 log units) away from the limit.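

In this assay compound 4 gives > 50000 nM, which is a limit and not a number. At this position, isopropyl in place of octyl gives an at least 1.9-fold higher number from compound 3 to compound 4 (0.28 log units; that floor lies within the scatter), and butyl in place of hydrogen gives an at least 1.2-fold higher number from compound 2 to compound 4 (0.08 log units; that floor lies within the scatter); both are floors, so neither change is shown to go beyond the scatter. Compound 4 is a second compound at the limit: the limit of > 50000 nM in this assay, at which 2 of the 4 values shown sit.

From the compounds shown here alone, the size of both steps stays open. Also open, going by these compounds, is whether an amine or a carboxylic acid in place of octyl would give a value inside the range of this assay.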